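The source may report more compounds than this note shows. Statements on the series, on what has been measured and on what is new or still open speak of the compounds shown alone.

Measured compounds in an assay on RBL-1 cells for inhibition of Polyunsaturated fatty acid 5-lipoxygenase (Rattus norvegicus); a higher number here means a weaker inhibitor, a lower number a stronger inhibitor:
compound 1 `O=C1NCCN(c2cccc(F)c2)N1` gives 19000 nM
compound 2 `O=C1NCCN(c2cccc([N+](=O)[O-])c2)N1` gives 49000 nM
compound 3 `O=C1NCCN(c2ccccn2)N1` gives 26000 nM

Compound 3 sits among numbers that all lie close to one another: its value is within the usual scatter of compound 1 and also within the scatter of compound 2, so no order among the three can be read from these figures. Compound 4 `COc1cccc(N2CCNC(=O)N2)n1` differs from compound 3 by methoxy in place of hydrogen on an aromatic carbon. Going by the values given here, only one measured step bears on this change: a 2.6-fold higher number from compound 1 to compound 2 (0.41 log units; beyond the scatter), which swaps one ring substituent for another on an aromatic carbon; no measured step adds a substituent in place of a hydrogen on the shared core's aryl ring. Among the compounds with values here, with that single modest step as the only guide, compound 4 is expected to show no change at the digits printed from compound 3 to compound 4 (within the scatter), a step no larger than the usual scatter in this assay. Compound 4 is therefore estimated at 26000 nM, with a range from 10000 nM to 70000 nM.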

Compound 4, half-maximal inhibitory concentration: 9500 nM
Estimate against measurement, compound 4: 2.7-fold (0.44 log units) above, outside the stated range (below it).
By their numbers in this assay, from the lowest: compounds 4, 1, 3 and 2 (each within the scatter of the next, the first and the last beyond it).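

In this assay, methoxy in place of hydrogen on an aromatic carbon next to the ring nitrogen gives a 2.7-fold lower number from compound 3 to compound 4 (0.44 log units; beyond the scatter), so a group added at this position moves the number beyond the scatter, and it moves it lower. Going by these compounds alone, the only earlier step, a 2.6-fold higher number from compound 1 to compound 2 (0.41 log units; beyond the scatter), swapped one ring substituent for another and went to a higher number, whereas this step puts a group where a hydrogen stood on the ring with 1 nitrogen. Nothing measured here explains the lower number.

As far as these compounds go, whether an amine, a hydroxyl group or a longer chain such as ethoxy at this same position would lower the number further or raise it remains open. Also open, from the compounds shown here alone, is whether methoxy on another carbon of this ring, or on the aryl ring of compound 1, would give a step of similar size.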